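Amino substitution on the benzamido arm of compound 2

This account rests on a few compounds, and the source may have more. Where it says the series, first, only, none or still open, it means among the compounds named here.

Measured compounds:
compound 1, `COc1ccc(OCC(=O)Nc2cccc(NC(=O)c3ccc(N(C)C)cc3)c2)cc1OC`, > 10000 nM
compound 2, `O=C(COc1ccc2c(=O)ccoc2c1)Nc1cccc(NC(=O)c2ccccc2)c1`, 16 nM

In an assay on isolated protein for inhibition of Rho-associated protein kinase 2 (Homo sapiens), read by scintillation counting, radiometric assay and 33P incorporation, with a stated time of 40 min, in the presence of a further agent that is not named here (a higher number here means a weaker inhibitor, a lower number a stronger inhibitor), compound 2 gives 16 nM. Compound 1 gives only a limit of the assay, > 10000 nM (the limit of > 10000 nM in this assay, at which 1 of the 2 values shown sits). Within the data shown here, compound 2 thus holds the only numerical value in this assay; the other result is a limit. Among the measured compounds shown here, compound 1 differs from compound 2 in more than one place, so the two results together show only that one compound sits at the limit and the other does not.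

Compound 3, `Nc1ccc(C(=O)Nc2cccc(NC(=O)COc3ccc4c(=O)ccoc4c3)c2)cc1`, is not yet measured. It differs from compound 2 by amino in place of hydrogen on an aromatic carbon. For the measured compounds named here, no step between measured compounds carries this same change, so nothing measured shows its effect on its own. The expectation in this assay is a step no larger than the scatter, in either direction; the estimated step from compound 2 to compound 3 is a 1.6-fold higher number from compound 2 to compound 3 (0.19 log units; within the scatter). Compound 3 is therefore expected to give about 25 nM, with a range from 8 nM to 80 nM.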

Compound 3, half-maximal inhibitory concentration: 83 nM
For compound 3 the middle estimate is 3.3-fold (0.52 log units) below the measured one; measured number above the stated range.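

In this assay, this position on the benzamido arm proves sensitive to a single change: amino in place of hydrogen on the aromatic carbon, para to a large group, gives a 5.2-fold higher number from compound 2 to compound 3 (0.71 log units; beyond the scatter). The earlier pair could not show this, as its two compounds differ in more than one place, whereas this step isolates phenyl to 4-aminophenyl on an otherwise unchanged structure, and compound 3 still gives a measured number, 83 nM. Nothing available on these compounds accounts for the size of this step.

One step at one position cannot show whether the higher number belongs to amino itself or would recur with other replacements for hydrogen, such as a fluorine, a carboxylic acid or an acetamido group at the same place. Also open, going by these compounds, is whether amino gives a step of the same size on the other aromatic carbons of this ring, and whether the same change would carry over to compounds with a different group at the far end of the chain.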